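The source may hold more compounds than are shown below. What is called first, only, known or untested is meant among the compounds shown, and "the series" means these compounds.

Measured in a functional assay on SK-N-SH cells (Homo sapiens) for inhibition, read by MTT assay, with a stated time of 72 h, tested at 50 uM; on this read-out higher numbers stand for more inhibition of growth at the one concentration tested and lower numbers for less inhibition of growth:
Compound 1 `C=CCc1ccc(OCc2cn(-c3cccc([N+](=O)[O-])c3)nn2)c(O)c1`: 68.9%
Compound 2 `C=CCc1cc(O)c(O)c(CN2CCC(C)CC2)c1`: 84.2%
Compound 3 `C=CCc1cc(O)c(O)c(CN2CCC(CCO)CC2)c1`: 40.6%

In this assay, compound 3 has the lowest of the three numbers, at 40.6%. This lies beyond the scatter from both compound 1 and compound 2.

The next compound is compound 4 `C=CCc1cc(O)c(O)c(CN2CCC(CO)CC2)c1`, and the change is hydroxy in place of hydroxymethyl on a saturated chain carbon bound to a saturated ring carbon. Read one bond further out, 2-hydroxyethyl gives way to hydroxymethyl.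

For the measured compounds named here, only one measured step falls at this place. It is a number 43.6 percentage points lower from compound 2 to compound 3 (beyond the scatter), with hydroxymethyl in place of hydrogen on a saturated chain carbon bound to a saturated ring carbon. Compound 1 differs too widely to help. The new change partly walks back that large step but keeps a hydroxy group, so only a modest recovery is expected, possibly within the scatter.

The expected step is a number 8.4 percentage points higher from compound 3 to compound 4 (within the scatter).

Compound 4 is estimated at 49%, with an expected range of 30% to 70%.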

Compound 4, percent growth inhibition at one concentration: 49.4%
For compound 4 the middle estimate is 0.4 percentage points below the measured one; the measured number falls inside the stated range.
By their numbers in this assay, from the lowest: compounds 3 and 4 (each within the scatter of the next); then compound 1; then compound 2.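

In this assay, cutting 2-hydroxyethyl back to hydroxymethyl gives a number 8.8 percentage points higher from compound 3 to compound 4 (within the scatter), so the length of this hydroxy-bearing chain makes no clear difference across these two compounds. Hydroxy in place of hydrogen on the saturated chain carbon bound to a saturated ring carbon still gives a number 34.8 percentage points lower from compound 2 to compound 4 (beyond the scatter), which shows that the large loss does not need the extra carbon of compound 3 and appears with hydroxymethyl as well. No measured information explains this loss.

Going by these compounds, whether an amine, a carboxylic acid or a methoxy group at this place would stay near the number of compound 2 or fall to the level of compound 3 and compound 4 remains open. So does whether a hydroxy-bearing chain longer than 2-hydroxyethyl would stay at that lower level.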